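The compounds below may be only part of what the source reports. "The series", "measured", "known", "first", "only" and "open" are said of these compounds alone.

In a functional assay for antagonist activity at transient receptor potential cation channel subfamily V member 1 (Rattus norvegicus), read by FLIPR (a higher number here means a more potent compound, by a factor of ten per unit of this negative logarithm, a lower number a less potent compound), two compounds have been measured so far:

compound 1, `O=C(Nc1ccccc1Br)N[C@@H]1CCN(c2cc(C(F)(F)F)ccn2)C1`, which gives 6.9;
compound 2, `O=C(NCCN1CCc2c(F)cccc21)Nc1ccccc1Br`, which gives 7.4.

Compound 2 stands at the top of these two numbers. For the measured compounds named here, its only neighbour, compound 1, sits lower in this assay by a margin that is beyond the usual scatter of repeated measurements, so compound 2 is the more potent of the pair. Going by the values given here, the two compounds share the bromophenyl urea part but differ in the rest of the molecule, and no single-point step between them is available.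

Compound 3, `O=C(NCCN1CCc2ccccc21)Nc1ccccc1Br`, has not yet been measured. It differs from compound 2 in one place only: hydrogen in place of fluoro on an aromatic carbon. This is a small change, removing a single fluorine from the fused ring system. Without a measured example of this exact change, the expectation is that compound 3 stays close to compound 2 in this assay, with a step from compound 2 to compound 3 of about a number 0.20 log units lower from compound 2 to compound 3 (within the scatter), which may well fall within the scatter. Compound 3 is therefore estimated at 7.2, with a likely range from 6.6 to 7.8.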

Compound 3, negative logarithm of the antagonist equilibrium constant: 6.8
Beside the measured number, compound 3's estimate is 0.40 log units above it; the range from low to high includes it.
By their numbers in this assay, from the lowest: compounds 3 and 1 (each within the scatter of the next); then compound 2.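

For the compounds shown here, replacing the fluoro with hydrogen, on an aromatic carbon of the fused ring system, gives a number 0.60 log units lower from compound 2 to compound 3 (beyond the scatter) in this assay and is the first change in this set that can be read on its own, since compounds 1 and 2 differ in more than one place. The swap removes one fluorine atom and adds no ring, no hydrogen-bond donor or acceptor and no charge, yet the step lies beyond the usual scatter, so this aromatic carbon is a place where even a single-atom change can register in this measurement. Nothing shown here explains why the fluoro counts for so much at this position.

The compounds shown leave open whether a chloro, a methyl or a methoxy group on this same aromatic carbon would match the fluoro, fall to the level of hydrogen or go beyond both. Going by these compounds alone, they also leave open whether the same swap would give a similar step in a compound with a longer chain joining the urea to the fused ring system, as this single pair is the only reading of the change so far.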